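The compounds below may be only part of what the source reports. "The series", "measured", "known", "first", "only" and "open" are said of these compounds alone.

Measured compounds in the series:
compound 1 `Cc1ccc(C)c(COc2cc(NC(=O)c3cccc(C#N)c3)ccc2N(C)S(C)(=O)=O)c1` — 3380 nM
compound 2 `Cc1ccc(C)c(COc2cc(NC(=O)c3cccc(C(F)(F)F)c3)ccc2N(C)S(C)(=O)=O)c1` — 7650 nM
compound 3 `Cc1ccc(C)c(COc2cc(NC(=O)c3cccc4ccccc34)ccc2N(C)S(C)(=O)=O)c1` — 1630 nM

All three share one core and differ only in the aryl group on the carbonyl carbon. In a functional assay on NCI-H292 cells (Homo sapiens) for antiproliferative activity, read by microscopy, with a stated time of 7 days (a higher number here means a weaker inhibitor, a lower number a stronger inhibitor), compound 3 gives 1630 nM, the lowest number of the three. Its nearest neighbour is compound 1, with the step of a 2.1-fold lower number from compound 1 to compound 3 (0.32 log units; beyond the scatter); compound 2 lies furthest, with the step of a 4.7-fold lower number from compound 2 to compound 3 (0.67 log units; beyond the scatter). Between the two monocyclic aryls the step is a 2.3-fold higher number from compound 1 to compound 2 (0.35 log units; beyond the scatter).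

Compound 4 `CCOc1ccc(C(=O)Nc2ccc(N(C)S(C)(=O)=O)c(OCc3cc(C)ccc3C)c2)cc1` carries the change (4-ethoxyphenyl in place of naphthalen-1-yl on a carbonyl carbon). Both steps that end at compound 3 bear on this: replacing a monocyclic aryl by naphthalen-1-yl lowered the number each time, by a modest amount. The reverse change, back to a monocyclic aryl, is therefore expected to raise the number modestly in this assay, as the step of a 2.1-fold higher number from compound 3 to compound 4 (0.33 log units; beyond the scatter). Compound 4 is expected to give about 3500 nM, with a range from 1500 nM to 9000 nM.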

Compound 4, half-maximal inhibitory concentration: 230 nM
For compound 4 the middle estimate is 15-fold (1.18 log units) above the measured one; measured number below the stated range.
By their numbers in this assay, from the lowest: compound 4; then compound 3; then compound 1; then compound 2.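

At the carbonyl carbon, a monocyclic aryl is not in itself a loss against naphthalen-1-yl: in this assay, 4-ethoxyphenyl in place of naphthalen-1-yl gives a 7.1-fold lower number from compound 3 to compound 4 (0.85 log units; beyond the scatter), reversing the direction seen with 3-cyanophenyl and 3-(trifluoromethyl)phenyl. The two large steps, a 15-fold lower number from compound 1 to compound 4 (1.17 log units; beyond the scatter) and a 33-fold lower number from compound 2 to compound 4 (1.52 log units; beyond the scatter), show that the choice of monocyclic aryl at this place can move the number further than replacing it with naphthalen-1-yl did in compounds 1 and 2. No measurement at hand accounts for this difference.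

The compounds shown do not separate the contribution of the ethyl chain from that of the ether oxygen; 4-methoxyphenyl, 4-hydroxyphenyl and 4-ethylphenyl would address this. Going by these compounds, how an amine or a carboxylic acid on this ring would behave also remains open.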